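A few compounds are considered here, and "the series" means these few. Any claim that something is new, unique, unknown or untested is made for them only; others in the source may bear on it.

Two compounds share a core carrying a phenyl-substituted pyrazole and an anilinomethyl arm. Compound 1 `COc1ccc(-c2nn(-c3ccccc3)cc2CNc2ccc(F)cc2)cc1` bears a methoxy on its outer aromatic ring; in a functional assay on MCF7 cells (Homo sapiens) for antiproliferative activity, read by MTT assay, with a stated time of 48 h (on this read-out higher numbers stand for weaker inhibition and lower numbers for stronger inhibition), compound 1 gives 5980 nM. Compound 2 `Cc1ccc(-c2nn(-c3ccccc3)cc2CNc2ccc(F)cc2)cc1` carries a methyl in place of that methoxy, and in this assay compound 2 gives 5880 nM. For the measured compounds named here, the single measured step, a 1.0-fold lower number from compound 1 to compound 2 (0.01 log units; within the scatter), is within the scatter, so compound 2 stands alongside compound 1 with no separation that can be read as a difference.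

Compound 3 `Cc1ccc(-c2nn(-c3ccccc3)cc2CNc2ccc(Cl)cc2)cc1` is the next compound. Its difference from compound 2 is chloro in place of fluoro on an aromatic carbon. No measured step among these compounds touches the halogen on the anilino ring: the only step known, from compound 1 to compound 2, concerns the methyl and methoxy on the other ring and was itself within the scatter. There is therefore no basis for expecting a step in this assay beyond the scatter in either direction. Compound 3 is accordingly expected to give about 5500 nM, within a range of 2500 nM to 12000 nM, corresponding to an estimated step of a 1.1-fold lower number from compound 2 to compound 3 (0.03 log units; within the scatter).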

Compound 3, half-maximal inhibitory concentration: 6020 nM
Compound 3: middle estimate off by 1.1-fold (0.04 log units), on the low side, and the stated range covers the measured number.
By their numbers in this assay, from the lowest: compounds 2, 1 and 3 (each within the scatter of the next).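

In this assay, for the compounds shown here, the exchange of 4-fluorophenyl for 4-chlorophenyl gives a 1.0-fold higher number from compound 2 to compound 3 (0.01 log units; within the scatter) and so provides the first measured step at this position, para to a large group, where the earlier step concerned only the methyl and methoxy on the other ring. Fluoro and chloro at this position cannot be told apart in this read-out, and with both single exchanges now within the scatter, the three compounds stand together with no order that can be read among them. Nothing measured here speaks to the reason for this result.

The compounds shown carry only a halogen at this position, so it remains open whether a larger or quite different group there, such as an amine, a carboxylic acid or a longer alkyl chain, would give a step beyond the scatter. The outer ring likewise shows only methyl and methoxy, which leaves open what a hydroxyl or a nitrile at that place would do, and whether either ring can separate these compounds at all.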